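A few compounds are considered here, and "the series" means these few. Any claim that something is new, unique, unknown or untested is made for them only; others in the source may bear on it.

Measured so far in an ADME assay on microsomes from liver (Homo sapiens) for metabolic stability, with a stated time of 10 min; a higher number here means that more of the compound is left, a lower number that less of the compound is left:
- compound 1 `COc1cc(OCc2ccccc2OC)c2cc(-c3cn4nc(OC)sc4n3)oc2c1`: compound 1 gives 82%
- compound 2 `COc1cc(OCc2cccc(O)c2)c2cc(-c3cn4nc(OC)sc4n3)oc2c1`: compound 2 gives 97%
- compound 3 `COc1cc(OC)c2cc(-c3cn4nc(OC)sc4n3)oc2c1`: compound 3 gives 86%

Compound 2 stands highest of the three in this assay. The step of a number 15 percentage points higher from compound 1 to compound 2 (beyond the scatter) lies beyond the scatter, as does the step of a number 11 percentage points lower from compound 2 to compound 3 (beyond the scatter); the step of a number 4 percentage points higher from compound 1 to compound 3 (within the scatter) stays within it.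

Compound 4 `COc1cc(OCc2cccc(OCc3ccccc3)c2)c2cc(-c3cn4nc(OC)sc4n3)oc2c1` differs from compound 2 by benzyl in place of hydrogen on an oxygen on an aromatic ring. Among the measured compounds shown here, the steps that bear on this are the two that leave compound 2: in both, the 3-hydroxyphenyl with its free hydroxy is lost, and both show a modest fall (a number 15 percentage points higher from compound 1 to compound 2 (beyond the scatter) read in reverse, a number 11 percentage points lower from compound 2 to compound 3 (beyond the scatter)). Compound 4 keeps the ring but caps the hydroxy with benzyl, so a step of the same sign and roughly the same size is expected, a modest drop rather than none. For compound 4 the estimate is therefore 80% (range 65% to 93%), which corresponds to an expected step of a number 17 percentage points lower from compound 2 to compound 4 (beyond the scatter).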

Compound 4, percent of the compound remaining: 85%
The estimate for compound 4 lay 5 percentage points below the measured number; low and high end bracket the measured number.
By their numbers in this assay, from the lowest: compounds 1, 4 and 3 (each within the scatter of the next); then compound 2.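

In this assay, replacing the hydrogen on the oxygen of compound 2 with benzyl gives a number 12 percentage points lower from compound 2 to compound 4 (beyond the scatter) and so shows that a modest fall does not require loss of the whole 3-hydroxyphenyl, since it also appears when that ring stays and only the hydroxy becomes benzyloxy. Compound 4 lies within the scatter of compound 1 and of compound 3, leaving compound 2, the only one of the four with a free hydroxy, alone at the top with no compound shown going against this. No measurement at hand accounts for the step.

From the compounds shown here alone, whether the fall follows from losing the hydroxy hydrogen or from adding benzyl stays open. Also open, going by these compounds, is whether an amine or a carboxylic acid in place of the hydroxy would hold the number of compound 2.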